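Swapping the fluorophenyl arm for a second pyridin-2-yl

The source may report more compounds than this note shows. Statements on the series, on what has been measured and on what is new or still open speak of the compounds shown alone.

Measured compounds:
- compound 1, `N=C(NCCCc1c[nH]cn1)NCCC(c1ccc(F)cc1)c1ccccn1`, 22.4 nM
- compound 2, `N=C(NCCCc1c[nH]cn1)NCCC(c1ccc(Cl)cc1)c1ccccn1`, 77.6 nM
- compound 3, `N=C(NCCCc1c[nH]cn1)NCCC(c1ccccn1)c1ccccc1F`, 437 nM

All three share a core and were tested in a functional assay on ileum for antagonist activity at histamine H1 receptor (Cavia porcellus); on this read-out lower numbers stand for tighter binding and higher numbers for weaker binding. Compound 1 gives the lowest number of the three; compound 2 is nearest to it, with a 3.5-fold higher number from compound 1 to compound 2 (0.54 log units; beyond the scatter), and compound 3 is furthest, with a 20-fold higher number from compound 1 to compound 3 (1.29 log units; beyond the scatter). Compound 2 and compound 3 are separated by a 5.6-fold higher number from compound 2 to compound 3 (0.75 log units; beyond the scatter).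

Compound 4, `N=C(NCCCc1c[nH]cn1)NCCC(c1ccccn1)c1ccccn1`, is not yet measured. It differs from compound 1 in one place: pyridin-2-yl in place of 4-fluorophenyl on a saturated chain carbon bound to an aromatic carbon and a saturated chain carbon. Within the data shown here, no measured step exchanges the carbon-only ring for a ring with a hetero atom, so none bears directly on this change. What the measured steps do show is that every alteration of the 4-fluorophenyl group made so far raised the number, modestly for compound 2 and strongly for compound 3. A loss of similar, modest size is therefore expected, in the direction of weaker binding, a 2.7-fold higher number from compound 1 to compound 4 (0.43 log units; beyond the scatter). For compound 4 the estimate in this assay is 60 nM, with a range from 20 nM to 200 nM.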

Compound 4, dissociation constant: 389 nM
Compound 4: middle estimate off by 6.5-fold (0.81 log units), on the low side; the measured number lies above the stated range.
By their numbers in this assay, from the lowest: compound 1; then compound 2; then compounds 4 and 3 (each within the scatter of the next).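

In this assay, among these compounds, the first exchange of the carbon-only ring for a ring with a hetero atom at this position proves to be a large step (a 17-fold higher number from compound 1 to compound 4 (1.24 log units; beyond the scatter)), and it also separates the new arm from 4-chlorophenyl (a 5.0-fold higher number from compound 2 to compound 4 (0.70 log units; beyond the scatter)). Pyridin-2-yl and 2-fluorophenyl, two quite different arms, cannot be told apart on this carbon (a 1.1-fold lower number from compound 3 to compound 4 (0.05 log units; within the scatter)), so a low number here is so far seen only with the 4-fluorophenyl arm and, less so, the 4-chlorophenyl arm. Nothing available bears on why this exchange costs so much.

The compounds shown leave open whether a pyridin-3-yl or a 4-methoxyphenyl arm would come close to compound 1. They also leave open whether a longer chain between this carbon and the shared core would change the cost of pyridin-2-yl.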